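The source may report more compounds than this note shows. Statements on the series, on what has been measured and on what is new or still open speak of the compounds shown alone.

Measured in a functional assay on MDA-MB-231 cells (Homo sapiens) for cytotoxicity, read by MTT assay, with a stated time of 48 h; on this read-out higher numbers stand for weaker inhibition and lower numbers for stronger inhibition:
- compound 1 `COc1cc(-c2ocnc2-c2cc(Br)c(OC)c(OC)c2)ccc1SC`: 760 nM
- compound 2 `COc1ccc(-c2ocnc2-c2cc(Br)c(OC)c(OC)c2)cc1SC`: 920 nM

Compound 2 at 920 nM and compound 1 at 760 nM lie within the scatter of each other, so neither stands apart on these numbers. Compound 3 `COc1ccc(-c2ocnc2-c2cc(Br)c(OC)c(OC)c2)cc1OC` has methoxy in place of methylsulfanyl on an aromatic carbon, ortho to a methoxy group and meta to a large group (methoxy in place of methylsulfanyl on an aromatic carbon). Within the data shown here, no measured step shows this exchange, so the expectation rests only on the two values. The expected 1.3-fold lower number from compound 2 to compound 3 (0.12 log units; within the scatter) in this assay stays within the scatter, with no firm direction. For compound 3 the estimated value is 700 nM, with an expected range of 200 nM to 2500 nM.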

Compound 3, half-maximal inhibitory concentration: 7830 nM
Compound 3: middle estimate off by 11-fold (1.05 log units), on the low side; measured number outside the range, above it.
By their numbers in this assay, from the lowest: compounds 1 and 2 (each within the scatter of the next); then compound 3.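

In this assay, methoxy in place of methylsulfanyl on an aromatic carbon, ortho to a methoxy group and meta to a large group, gives an 8.5-fold higher number from compound 2 to compound 3 (0.93 log units; beyond the scatter), beyond the scatter. The same exchange starting from compound 1 gives a 10-fold higher number from compound 1 to compound 3 (1.01 log units; beyond the scatter), so the methylsulfanyl group matters in both compounds, something the pair of compound 1 and compound 2 alone could not show. Nothing measured here accounts for the loss. Still open, as far as these compounds go, is whether ethylsulfanyl, a longer chain on the sulfur, or an amine at this place would retain the numbers of compound 1 and compound 2.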